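From 4-bromophenyl to phenethyl on the sulfur

The compounds below may be only part of what the source reports. "The series", "measured", "known", "first", "only" and "open" are said of these compounds alone.

Within the data shown here, in a functional assay on A549 cells (Homo sapiens) for inhibition, read by CCK-8 assay, with a stated time of 72 h, tested at 2 uM (a lower number here means less inhibition of growth, a higher number more inhibition of growth at the concentration tested), compound 1 (`CCc1ccc(SCc2ccc(C(=O)Nc3ccccc3N)cc2)cc1`) gives 53.6%, and compound 2 (`Nc1ccccc1NC(=O)c1ccc(CSc2ccc(Br)cc2)cc1`) gives 33.2%, the lower of the two numbers so far. Compound 3 (`Nc1ccccc1NC(=O)c1ccc(CSCCc2ccccc2)cc1`) carries phenethyl in place of 4-bromophenyl on a sulfur. Among the measured compounds shown here, only one measured step bears on this change, and only indirectly. That step, a number 20.4 percentage points lower from compound 1 to compound 2 (beyond the scatter), is modest and beyond the scatter, and it exchanges ethyl for bromo on an aromatic carbon. Compound 3 also lacks the bromine, but its whole group on the sulfur differs, so the step cannot be carried over in full. A modest rise in this assay is therefore expected, though one within the scatter remains possible. The expected change is a number 9.8 percentage points higher from compound 2 to compound 3 (within the scatter). For compound 3, the estimated value is 43%, with an expected range of 24% to 62%.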

Compound 3, percent growth inhibition at one concentration: 44.9%
For compound 3 the middle estimate is 1.9 percentage points below the measured one; low and high end bracket the measured number.
By their numbers in this assay, from the lowest: compound 2; then compounds 3 and 1 (each within the scatter of the next).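

In this assay, the sulfur position accepts a group other than a substituted phenyl: phenethyl in place of 4-bromophenyl gives a number 11.7 percentage points higher from compound 2 to compound 3 (beyond the scatter). Phenethyl in place of 4-ethylphenyl gives a number 8.7 percentage points lower from compound 1 to compound 3 (within the scatter), so this read-out does not separate these two groups on the sulfur, and among the three compounds only compound 2, with its 4-bromophenyl, stands apart as the lowest. Nothing measured here gives a cause for these differences.

Whether phenethyl itself or any group without bromine accounts for the higher numbers stays open, since three compounds cannot settle that. Going by these compounds, what a longer chain such as 3-phenylpropyl, or an amine or a carboxylic acid at the end of the chain, would do on the sulfur also stays open.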